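From compound 1 to compound 3 in a cytotoxicity read-out

This account rests on a few compounds, and the source may have more. Where it says the series, first, only, none or still open, it means among the compounds named here.

Compound 1 `CCOc1ccc(NC(=O)/C(C#N)=C(\NC)SC)cc1` was tested in an ADME assay on TERT-RPE1 cells (Homo sapiens) for cytotoxicity, read by resazurin assay, with a stated time of 48 h; on this read-out higher numbers stand for weaker inhibition and lower numbers for stronger inhibition. In this assay compound 1 gives > 100000 nM, which is a limit of the assay rather than a measured number. Compound 2 `C=CCNc1[nH]nc(N)c1C(=O)Nc1ccc(OCC)cc1` was run in the same read-out. In this assay compound 2 gives > 100000 nM, again a limit. Compound 1 therefore stands at the ceiling of the values shown, since both of them sit at the limit of > 100000 nM in this assay, at which 2 of the 2 values shown sit, and neither compound can be ranked against the other on these numbers.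

Compound 3 `CCOc1ccc(NC(=O)/C(C#N)=C(\Nc2ccccc2)SC)cc1` is the next compound, and it has not yet been measured. It differs from compound 1 in one place: phenyl in place of methyl on an amine nitrogen. For the measured compounds named here, no step between two measured compounds is available to set the scale of such a change, and neither value shown is a number. The expectation is therefore that the step of a number no higher from compound 1 to compound 3 (the limit leaves the size open) amounts to none beyond the usual scatter, and that compound 3 also ends at the limit. Compound 3 is estimated at 100000 nM, with a range from 30000 nM to 300000 nM.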

Compound 3, half-maximal inhibitory concentration: > 100000 nM
Compound 3 gave a limit, no number (the forecaster's own chance of this, stated with the estimate: 75%); the middle value sits exactly at the limit.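

In this assay compound 3 gives > 100000 nM, which is a limit and not a number. No step can be read from compound 1 to compound 3, since both stand at the same limit: the limit of > 100000 nM in this assay, at which 3 of the 3 values shown sit.

The compounds shown leave open whether any change to the shared core would give a measured number in this assay.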